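Quinoline-bearing benzoxazinones: aryl substituent swap, methoxy to chloro

The source may hold more compounds than are shown below. What is called first, only, known or untested is meant among the compounds shown, and "the series" means these compounds.

Measured so far:
compound 1 `COc1ccc(N2C(=O)COc3ccc(-c4cnc5ccccc5c4)cc32)cc1` — > 40000 nM
compound 2 `O=C1COc2ccc(-c3cnc(Cl)c(NS(=O)(=O)c4ccc(F)cc4)c3)cc2N1c1ccc(F)cc1` — > 40000 nM
compound 3 `O=C1COc2ccc(-c3ccc(O)cc3)cc2N1` — > 40000 nM

In a functional assay on A-375 cells (Homo sapiens) for antiproliferative activity, read by MTT assay, with a stated time of 72 h (on this read-out lower numbers stand for stronger inhibition and higher numbers for weaker inhibition), compound 1 gives only a limit, > 40000 nM. Compound 2 likewise gives a limit in this assay. Compound 3 also gives a limit. For the measured compounds named here, all three measured values sit at the limit of > 40000 nM in this assay, at which 3 of the 3 values shown sit, so no compound of the set has a number, and nothing places compound 1 above or below the others.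

Compound 4 `O=C1COc2ccc(-c3cnc4ccccc4c3)cc2N1c1ccc(Cl)cc1` differs from compound 1 by chloro in place of methoxy on an aromatic carbon. Going by the values given here, no measured pair differing in one place is available, so the size of this step in this assay is unknown from the data. Compound 4 is expected to remain at the limit as well, with an estimated step of a number no higher from compound 1 to compound 4 (the limit leaves the size open) and an estimated value of 40000 nM, between 8000 nM and 100000 nM.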

Compound 4, half-maximal inhibitory concentration: > 40000 nM
Compound 4 ended at the assay's limit (the forecaster's own chance of this, stated with the estimate: 75%); the middle value lies on the limit itself.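

No step can be read from compound 1 to compound 4, since both stand only as limits in this assay: the limit of > 40000 nM in this assay, at which 4 of the 4 values shown sit.

The compounds shown leave open which structural change, if any, would give a measurable value in this assay.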